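The source may report more compounds than this note shows. Statements on the series, on what has been measured and on what is new or still open speak of the compounds shown alone.

Measured so far:
In a toxicity assay on MCF-10A cells (Homo sapiens) for inhibition, read by MTT assay, with a stated time of 72 h (on this read-out lower numbers stand for stronger inhibition of growth and higher numbers for weaker inhibition of growth), compound 1 `O=S(=O)(NCCCNCc1ccccc1Cl)c1cc(C(F)(F)F)cc(C(F)(F)F)c1` gives 11000 nM.
In this assay compound 2 `O=S(=O)(NCCCNCc1ccc(Cl)c(Cl)c1)c1cc(C(F)(F)F)cc(C(F)(F)F)c1` gives 3000 nM.
In this assay compound 3 `O=S(=O)(NCCCNCC1COc2ccccc2O1)c1cc(C(F)(F)F)cc(C(F)(F)F)c1` gives 3200 nM.

Compound 3 stands second highest of these three numbers. Its nearest neighbour is compound 2, and the step of a 1.1-fold higher number from compound 2 to compound 3 (0.03 log units; within the scatter) lies within the scatter, so the two cannot be told apart. Its furthest neighbour is compound 1, and that gap is beyond the scatter: a 3.4-fold lower number from compound 1 to compound 3 (0.54 log units; beyond the scatter).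

Compound 4 `O=S(=O)(NCCCNCc1ccccc1)c1cc(C(F)(F)F)cc(C(F)(F)F)c1` has not yet been measured. It differs from compound 3 in one place: phenyl in place of 2,3-dihydro-1,4-benzodioxin-2-yl on a saturated chain carbon bound to an amine nitrogen.

Among the compounds with values here, no measured step swaps exactly these two groups, so the expectation rests on what the three measured compounds show. The step of a 3.7-fold lower number from compound 1 to compound 2 (0.56 log units; beyond the scatter) shows that 3,4-dichlorophenyl gives a clearly lower number than 2-chlorophenyl, and 2,3-dihydro-1,4-benzodioxin-2-yl in compound 3 sits level with the dichlorophenyl of compound 2. Compound 4 carries a phenyl with no chlorine at all, so the number is expected to rise, probably to about where compound 1 lies or somewhat beyond, though this is an extrapolation. The expected step is a 3.1-fold higher number from compound 3 to compound 4 (0.49 log units; beyond the scatter). Compound 4 is estimated at 10000 nM, with a likely range from 3500 nM to 30000 nM.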

Compound 4, concentration for 50% growth inhibition: 13000 nM
Compound 4: the middle estimate sits 1.3-fold (0.11 log units) below what was measured, within the range that was stated.
By their numbers in this assay, from the lowest: compounds 2 and 3 (each within the scatter of the next); then compounds 1 and 4 (each within the scatter of the next).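

In this assay, hydrogen in place of chloro on an aromatic carbon gives no difference that can be told apart, with a 1.2-fold higher number from compound 1 to compound 4 (0.07 log units; within the scatter), so the single chloro of the 2-chlorophenyl in compound 1 has no visible effect on this read-out. The plain phenyl therefore groups with 2-chlorophenyl, while the lower numbers belong to the other two groups on this saturated chain carbon bound to an amine nitrogen: 3,4-dichlorophenyl, with a 4.3-fold higher number from compound 2 to compound 4 (0.64 log units; beyond the scatter), and 2,3-dihydro-1,4-benzodioxin-2-yl, with a 4.1-fold higher number from compound 3 to compound 4 (0.61 log units; beyond the scatter). A chlorine is thus neither sufficient at this position, as the 2-chlorophenyl shows, nor required for the lower number, as the chlorine-free 2,3-dihydro-1,4-benzodioxin-2-yl shows.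

Nothing available here explains why these groups separate as they do. Going by these compounds, it remains open whether a single chloro placed elsewhere on the phenyl, a phenyl carrying a methoxy group, or a pyridine ring in place of the phenyl would fall with the lower pair or the higher pair.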